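This account rests on a few compounds, and the source may have more. Where it says the series, first, only, none or still open, it means among the compounds named here.

Compound 1 `C[C@H](NC(=O)[C@@H]1CCCN1C)c1ccc(NC(=O)N2CC(c3cccnc3)C2)cc1`: 5.7 nM
Compound 2 `CCC(=O)N[C@@H](C)c1ccc(NC(=O)N2CC(c3cccnc3)C2)cc1`: 25 nM

Both numbers come from a functional assay on A2780 cells (Homo sapiens) for antiproliferative activity, read by CellTiter-Glo, with a stated time of 72 h; on this read-out higher numbers stand for weaker inhibition and lower numbers for stronger inhibition. Of the two, compound 2 has the higher value, 25 nM, so it is the weaker inhibitor. Among the measured compounds shown here, the one measured step is a 4.4-fold higher number from compound 1 to compound 2 (0.64 log units; beyond the scatter).

The next compound, compound 3 `CCC(=O)N[C@@H](C)c1ccc(NC(=O)N2CC(c3ccc(N)nc3)C2)cc1`, keeps the propanamide side of compound 2 and changes the pyridine ring, with amino in place of hydrogen on an aromatic carbon.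

The measured step changed a different place, the group on the carbonyl carbon. It therefore shows only how far one change has moved the number in this small set. For the measured compounds named here, no measured step tests an amino group, so no direction can be argued from the data, and no shift beyond the scatter is assumed in this assay.

The expected change is a 1.3-fold lower number from compound 2 to compound 3 (0.10 log units; within the scatter). For compound 3 the estimate is 20 nM, with an expected range of 6 nM to 70 nM.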

Compound 3, half-maximal inhibitory concentration: 58 nM
Estimate against measurement, compound 3: 2.9-fold (0.46 log units) below; the range from low to high includes it.
By their numbers in this assay, from the lowest: compound 1; then compound 2; then compound 3.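

In this assay the pyridine ring proves sensitive to substitution: placing amino on the aromatic carbon next to the ring nitrogen, which turns pyridin-3-yl into 6-aminopyridin-3-yl, gives a 2.3-fold higher number from compound 2 to compound 3 (0.37 log units; beyond the scatter) and so weaker inhibition. The earlier step changed only the group on the carbonyl carbon, so it said nothing about this ring, whereas here a single added nitrogen atom moves the number modestly but beyond the scatter. Nothing measured here explains why the amino group has this effect.

Going by these compounds, it remains open whether a smaller or different group at this carbon, such as fluorine, methyl or methoxy, would also raise the number. On these data alone, it is also open whether amino would cost as much on the 1-methylpyrrolidin-2-yl amide of compound 1.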